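The compounds below may be only part of what the source reports. "The series", "measured", "known", "first", "only" and "open" are said of these compounds alone.

Measured so far:

Compound 1, `CCCCCCCC(=O)c1c(OC)c(Cl)c(OC)c(Cl)c1OC`, gives 51400 nM.
Compound 2, `CCCCCC(=O)c1c(O)c(Cl)c(C)c(Cl)c1O`, gives 13800 nM.
Compound 3, `CCCC(=O)c1c(O)c(Cl)c(O)c(Cl)c1O`, gives only a limit of the assay, > 100000 nM.

These numbers come from an ADME assay on the whole organism (strain S2) for cytotoxicity, with Drosophila as the target, read by WST assay; a lower number here means that less compound is tolerated, a higher number that more compound is tolerated. Among the two compounds that returned a number, compound 1 stands highest, so more of it is tolerated than of compound 2, whose number is lower by a gap beyond the usual scatter. Compound 3 stands apart: its result is not a number but (the limit of > 100000 nM in this assay, at which 1 of the 3 values shown sits), so it cannot be ranked against the others.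

The compound not yet measured is compound 4, `CCCCCCC(=O)c1c(OC)c(Cl)c(OC)c(Cl)c1OC`. It differs from compound 1 in one place: hydrogen in place of methyl on a saturated chain carbon, six bonds along the chain from a carbonyl carbon. In plain terms, the saturated chain on the carbonyl is shortened by one carbon, and everything on the ring stays as in compound 1. Within the data shown here, no pair of measured compounds shows this single change, so the size of the step is open. Removing one carbon from a long chain is a small change, and the expectation is a step of no size beyond the scatter, or a modest move towards a higher number. Compound 4 is therefore estimated at 60000 nM, with a range from 30000 nM to 120000 nM, meaning the expected step of a 1.2-fold higher number from compound 1 to compound 4 (0.07 log units; within the scatter) is small.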

Compound 4, half-maximal cytotoxic concentration: 140000 nM
Compound 4: the middle estimate sits 2.3-fold (0.37 log units) below what was measured; measured number outside the range, above it.
By their numbers in this assay, from the lowest: compound 2; then compound 1; then compound 4.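

In this assay, shortening the saturated chain on the carbonyl by one carbon, with hydrogen in place of methyl six bonds along the chain from a carbonyl carbon, gives a 2.7-fold higher number from compound 1 to compound 4 (0.44 log units; beyond the scatter). This place on the chain therefore matters in this assay: with everything on the ring unchanged, losing a single carbon moves the number beyond the usual scatter, towards more compound being tolerated. Nothing shown here bears on why this step occurs.

Among these compounds, with only one pair, this is a single step in one direction, so it remains open whether cutting the chain further would keep raising the number, or whether a longer chain would lower it. Also open, on these data alone, is how the number would move with an amine or a carboxylic acid at this place on the chain, and whether the same step would appear with hydroxyl groups on the ring in place of the methoxy groups.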